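A few compounds are considered here, and "the series" means these few. Any claim that something is new, unique, unknown or untested is made for them only; others in the source may bear on it.

Compound 1 `Cc1nnc(SCC(=O)[C@H](CC(=O)O)NC(=O)[C@@H](NC(=O)COc2cccc3ccccc23)C(C)C)s1` and compound 2 `CC(C)[C@H](NC(=O)COc1cccc2ccccc12)C(=O)N[C@@H](CC(=O)O)C(=O)COc1cc2ccccc2cn1` share one core and differ on the saturated chain carbon bound to a carbonyl carbon, where compound 2 carries (isoquinolin-3-yl)oxy in place of (5-methyl-1,3,4-thiadiazol-2-yl)sulfanyl. In a functional assay on Jurkat cells (Homo sapiens) for inhibition (a higher number here means a weaker inhibitor, a lower number a stronger inhibitor), compound 1 gives 190000 nM. For compound 2 this assay reports only a limit, > 200000 nM, and not a number. The step of an at least 1.0-fold higher number from compound 1 to compound 2 (0.02 log units; that floor lies within the scatter) is thus only a floor, as the limit of > 200000 nM in this assay, at which 1 of the 2 values shown sits, shows. Compound 3 `CC(C)[C@H](NC(=O)COc1cccc2ccccc12)C(=O)N[C@@H](CC(=O)O)C(=O)COc1nccc2ccccc12` is the next change: isoquinolin-1-yl in place of isoquinolin-3-yl on an oxygen on a saturated carbon. Among the measured compounds shown here, no measured step bears on this exchange, and the only anchor for compound 2 is its limit, so in this assay no step beyond the scatter is expected. The expected step is a step that the limit leaves unreadable from compound 2 to compound 3. Compound 3 is estimated at 250000 nM, with an expected range from 100000 nM to 600000 nM. A further limit rather than a number from this assay is judged likely for compound 3.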

Compound 3, half-maximal inhibitory concentration: 106000 nM
Estimate against measurement, compound 3: 2.4-fold (0.37 log units) above; measured number inside the range.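

Replacing isoquinolin-3-yl with isoquinolin-1-yl on an oxygen on a saturated carbon gives an at least 1.8-fold lower number from compound 2 to compound 3 (0.27 log units; that floor lies within the scatter), so this exchange can be read only as a floor: the limit of > 200000 nM in this assay, at which 1 of the 3 values shown sits.

At the saturated chain carbon bound to a carbonyl carbon, (isoquinolin-1-yl)oxy in place of (5-methyl-1,3,4-thiadiazol-2-yl)sulfanyl gives a 1.8-fold lower number from compound 1 to compound 3 (0.25 log units; within the scatter), so these two groups cannot be told apart in this assay. Neither printed step therefore shows a change at this position beyond the scatter.

As far as these compounds go, whether the true gap between isoquinolin-3-yl and isoquinolin-1-yl exceeds the scatter remains open, since only a floor is available for that exchange. Also open, from the compounds shown here alone, is how this assay responds at this position to a different kind of group, such as an amine or a longer alkyl chain in place of (isoquinolin-1-yl)oxy.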